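The source may report more compounds than this note shows. Statements on the series, on what has been measured and on what is new or still open speak of the compounds shown alone.

Measured compounds in an ADME assay on BJ cells (Homo sapiens) for antiproliferative activity, with a stated time of 72 h; a lower number here means that less compound is needed, a higher number that more compound is needed for the effect:
Compound 1 `COC(=O)c1cc(=O)c2c(OC)cc(OC)cc2n1C`: in this assay compound 1 gives only a limit, > 37900 nM.
Compound 2 `COC(=O)c1cc(=O)c2cc(NC(=O)Nc3ccc(Cl)c(C(F)(F)F)c3)ccc2[nH]1`: in this assay compound 2 gives only a limit, > 12600 nM.
Compound 3 `COC(=O)c1cc(=O)c2cc(NC(=O)Nc3ccc(Cl)c(Cl)c3)ccc2[nH]1`: in this assay compound 3 gives only a limit, > 12600 nM.

Compound 3 therefore stands at a limit and not at a number. Across the set, two of the three values sit at the limit of > 12600 nM in this assay, at which 2 of the 3 values shown sit, and one at the limit of > 37900 nM in this assay, at which 1 of the 3 values shown sits, so no measured compound yields a readable value in this assay. Among the compounds with values here, the only step between measured compounds that differ in one place, a step that the two limits leave unreadable from compound 2 to compound 3, is unreadable with both ends at a limit.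

Compound 4 `COC(=O)c1cc(=O)c2cc(NC(=O)NCc3ccccc3)ccc2[nH]1` differs from compound 3 by benzyl in place of 3,4-dichlorophenyl on an amide-type nitrogen. Within the data shown here, no measured step bears on this change; the step from compound 2 to compound 3 shows only that both remain at the limit. Nothing in the set points to a readable value, so compound 4 is expected to stay at a limit too. The step that the limit leaves unreadable from compound 3 to compound 4 is estimated as none beyond the scatter, most likely unreadable. For compound 4 the estimate is 25000 nM, with a range from 9000 nM to 70000 nM.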

Compound 4, half-maximal effective concentration: > 19500 nM
Compound 4: only a limit was reported; the forecaster's own chance of this, stated with the estimate: 80%; the middle value lies beyond the limit too.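

Compound 3 and compound 4 both give only limits in this assay, so the change from 3,4-dichlorophenyl to benzyl yields no readable step. The compounds shown leave open whether any member of the series reaches a readable half-maximal effective concentration in this assay.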